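This account rests on a few compounds, and the source may have more. Where it says the series, first, only, none or still open, it means among the compounds named here.

Of the compounds shown here, three sharing one core have been measured in a physicochemical assay for lipophilicity; a higher number here means a more lipophilic compound, a lower number a more polar compound. Compound 1 `CN1CCN(c2ccc3ncc(-c4cnc(Nc5ncccc5F)nc4)n3n2)CC1` gives 2.2, compound 2 `Fc1cccnc1Nc1ncc(-c2cnc3ccc(NCCN4CCCC4)nn23)cn1` gives 1.5, and compound 3 `CN1CCC(Oc2ccc3ncc(-c4cnc(Nc5ncccc5F)nc4)n3n2)CC1` gives 1.5, which places compound 3 level with compound 2 and under compound 1. The unmeasured compound 4 `CN1CCC(Cc2ccc3ncc(-c4cnc(Nc5ncccc5F)nc4)n3n2)CC1` carries (1-methylpiperidin-4-yl)methyl in place of (1-methylpiperidin-4-yl)oxy on an aromatic carbon. Among the measured compounds shown here, no measured step makes this exact exchange. The nearest guides swap whole side chains at this place, a number 0.70 log units lower from compound 1 to compound 3 (beyond the scatter) and no change at the digits printed from compound 2 to compound 3 (within the scatter). The first shows that a modest shift at this place can exceed the scatter. With an oxygen giving way to a carbon, a modest rise is expected, an estimated a number 0.50 log units higher from compound 3 to compound 4 (beyond the scatter). Compound 4 is expected at 2, within an estimated range of 1.6 to 2.5.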

Compound 4, distribution coefficient: 1.3
For compound 4 the middle estimate is 0.70 log units above the measured one; measured number below the stated range.
By their numbers in this assay, from the lowest: compounds 4, 2 and 3 (each within the scatter of the next); then compound 1.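

In this assay the exchange of (1-methylpiperidin-4-yl)oxy for (1-methylpiperidin-4-yl)methyl, with one hydrogen-bond acceptor fewer, stays within the scatter (a number 0.20 log units lower from compound 3 to compound 4 (within the scatter)). Compound 4 also lies within the scatter of the chain in compound 2 (a number 0.20 log units lower from compound 2 to compound 4 (within the scatter)), while compound 1 stands apart (a number 0.90 log units lower from compound 1 to compound 4 (beyond the scatter)), so among these four compounds only the one carrying 4-methylpiperazin-1-yl differs beyond the scatter. Nothing at hand explains this result. On these data alone, whether a morpholin-4-yl group at this place would stand with compound 1 or with the other three remains open.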